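The source may hold more compounds than are shown below. What is called first, only, known or untested is meant among the compounds shown, and "the series" means these compounds.

Measured so far in a functional assay on KB cells (nasopharynx, Homo sapiens) for antiproliferative activity; on this read-out higher numbers stand for weaker inhibition and lower numbers for stronger inhibition:

Compound 1, `COc1ccc(S(=O)(=O)Nc2cccc3cc[nH]c23)cc1`: 0.67 ug/mL
Compound 2, `N#Cc1ccc(S(=O)(=O)Nc2cccc3cc[nH]c23)cc1`: 8.5 ug/mL
Compound 3, `COc1ccc(S(=O)(=O)Nc2cccc3c(Cl)c[nH]c23)cc1`: 0.55 ug/mL

Compound 4, `N#Cc1ccc(S(=O)(=O)Nc2cccc3c(Cl)c[nH]c23)cc1`, has no result yet in this assay.

Two single-point changes connect the measured compounds. From compound 1 to compound 2 the change is cyano in place of methoxy on an aromatic carbon, and in this assay it produced a 13-fold higher number from compound 1 to compound 2 (1.10 log units; beyond the scatter). From compound 1 to compound 3 the change is chloro in place of hydrogen on an aromatic carbon, and in this assay it produced a 1.2-fold lower number from compound 1 to compound 3 (0.09 log units; within the scatter); compound 1 and compound 3 therefore sit within the scatter of each other, and no order between them is claimed. Compound 2 stands beyond the scatter from both.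

Compound 4 relates to compound 3 by cyano in place of methoxy on an aromatic carbon. Within the data shown here, this is the same change as the one from compound 1 to compound 2, the place descriptions being identical word for word; the two cores differ only by chloro in place of hydrogen on an aromatic carbon. Among the measured compounds shown here, the pair compound 1 and compound 2 is the only prior instance of this change, so the expectation for compound 4 rests on a single step. Because that step was a 13-fold higher number from compound 1 to compound 2 (1.10 log units; beyond the scatter), and because the core difference gave only a 1.2-fold lower number from compound 1 to compound 3 (0.09 log units; within the scatter), the change is expected to carry over largely unchanged, giving an expected 13-fold higher number from compound 3 to compound 4 (1.12 log units; beyond the scatter). On that basis compound 4 is estimated at 7.2 ug/mL in this assay, with an expected range from 3 ug/mL to 17 ug/mL.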

Compound 4, half-maximal inhibitory concentration: 11 ug/mL
The estimate for compound 4 lay 1.5-fold (0.18 log units) below the measured number; the measured number falls inside the stated range.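

In this assay, cyano in place of methoxy on an aromatic carbon gave a 20-fold higher number from compound 3 to compound 4 (1.30 log units; beyond the scatter), and this step on the core carrying chloro agrees with the earlier one on the core without it: the same change on two cores in this assay, a 13-fold higher number (1.10 log units; beyond the scatter) from compound 1 to compound 2 and a 20-fold higher number (1.30 log units; beyond the scatter) from compound 3 to compound 4, 1.6-fold (0.20 log units) apart, within the scatter of two such steps. Chloro in place of hydrogen on an aromatic carbon gave a 1.3-fold higher number from compound 2 to compound 4 (0.11 log units; within the scatter), and it remains a step within the scatter whether methoxy or cyano is present: the same change on two cores in this assay, a 1.2-fold lower number (0.09 log units; within the scatter) from compound 1 to compound 3 and a 1.3-fold higher number (0.11 log units; within the scatter) from compound 2 to compound 4, 1.6-fold (0.20 log units) apart, within the scatter of two such steps. Across these four compounds, each change carries from one core to the other with no gap beyond the scatter, but this rests on a single pair of steps for each change, and it shows neither why the cyano compounds give the higher numbers nor how either change would behave on a different core.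

Still open, on these data alone, is where other groups in the place of methoxy or cyano, such as an amine, a carboxylic acid or a longer alkoxy chain, would fall on either core. Also open, as far as these compounds go, is whether a group such as bromo or methyl in the place taken by chloro would likewise leave the number within the scatter.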